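A few compounds are considered here, and "the series" means these few. Any claim that something is new, unique, unknown or untested is made for them only; others in the source may bear on it.

Measured so far:
Compound 1 `C[C@H](NC(=O)C1CCOCC1)c1ccc(NC(=O)[C@H]2C[C@@H]2c2cccnc2)cc1`: 3 nM
Compound 2 `C[C@H](NC(=O)c1ccccc1)c1ccc(NC(=O)[C@H]2C[C@@H]2c2cccnc2)cc1`: 1 nM

Both values come from a functional assay on A2780 cells (Homo sapiens) for antiproliferative activity, read by CellTiter-Glo, with a stated time of 4 days; on this read-out higher numbers stand for weaker inhibition and lower numbers for stronger inhibition. Among the measured compounds shown here, compound 2 holds the lower of the two numbers, and the gap to its only neighbour is a 3.0-fold lower number from compound 1 to compound 2 (0.48 log units; beyond the scatter). Compound 3 `C[C@H](NC(=O)c1ccc(C#N)cc1)c1ccc(NC(=O)[C@H]2C[C@@H]2c2cccnc2)cc1` is the next analogue, with cyano in place of hydrogen on an aromatic carbon, para to a large group, turning phenyl into 4-cyanophenyl. For the measured compounds named here, no measured compound yet carries a substituent on that phenyl. Going by the values given here, the sole guide is the change on the same carbonyl carbon, a 3.0-fold lower number from compound 1 to compound 2 (0.48 log units; beyond the scatter), which is modest even though it replaces a whole group. A smaller edit at that site is therefore expected to move the number little, and in no firm direction, possibly not beyond the scatter. The estimated change is a 1.5-fold higher number from compound 2 to compound 3 (0.18 log units; within the scatter). For compound 3 the expected value in this assay is 1.5 nM, within an estimated range of 0.5 nM to 5 nM.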

Compound 3, half-maximal inhibitory concentration: 4 nM
Estimate against measurement, compound 3: 2.7-fold (0.43 log units) below, and the stated range covers the measured number.
By their numbers in this assay, from the lowest: compound 2; then compounds 1 and 3 (each within the scatter of the next).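

In this assay, the first substituent on this phenyl weakens inhibition: cyano on the aromatic carbon para to a large group gives a 4.0-fold higher number from compound 2 to compound 3 (0.60 log units; beyond the scatter), so this position responds even to a group of 2 heavy atoms. The advantage of phenyl over oxan-4-yl on the carbonyl carbon does not carry over to 4-cyanophenyl, which cannot be told apart from the oxan-4-yl amide, with a 1.3-fold higher number from compound 1 to compound 3 (0.12 log units; within the scatter). No measurement available here accounts for the shift.

As far as these compounds go, whether the loss belongs to cyano itself or to any substituent at this carbon stays open; a fluorine atom, a methoxy group or an amine there could separate the two. The compounds shown also leave open whether cyano on another carbon of this ring would act alike.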